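The source may hold more compounds than are shown below. What is called first, only, known or untested is meant among the compounds shown, and "the series" means these compounds.

Three compounds that share one core were tested in a functional assay on the whole organism for inhibition, with Mus musculus as the target, read by paw edema, with a stated time of 180 min, at a dose of 200 mg/kg by the oral route; a higher number here means a stronger effect of the compound at the dose given, a lower number a weaker effect. Compound 1 `CNC(=S)NNC(=O)Cn1c(=O)oc2ccc(C)cc21` gives 71.6%. Compound 2 `CCCn1c(Cn2c(=O)oc3ccc(C)cc32)n[nH]c1=S` gives 44.3%, the second highest of the three numbers. Compound 3 `CCCNc1nnc(Cn2c(=O)oc3ccc(C)cc32)s1` gives 39.4%, a number within the scatter of compound 2, while compound 1 sits beyond the scatter above compound 2. Compound 4 `CCn1c(Cn2c(=O)oc3ccc(C)cc32)n[nH]c1=S` has not yet been measured in this assay. It differs from compound 2 by hydrogen in place of methyl on a saturated chain carbon, two bonds along the chain from an aromatic nitrogen, which reads as propyl to ethyl. Among the measured compounds shown here, no measured pair shows a step of this kind, so nothing here indicates that shortening the chain by one carbon moves the read-out; a step no larger than the scatter is expected. Compound 4 is therefore estimated at about 42% in this assay, between 30% and 55%. The expected step is a number 2.3 percentage points lower from compound 2 to compound 4 (within the scatter).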

Compound 4, a percentage reported as inhibition, in the whole organism at one dose (the size of the read-out at that dose, not a potency): 31.8%
Compound 4: middle estimate off by 10.2 percentage points, on the high side; the range from low to high includes it.
By their numbers in this assay, from the lowest: compounds 4, 3 and 2 (each within the scatter of the next, the first and the last beyond it); then compound 1.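

In this assay, among the compounds shown here, the change from propyl to ethyl gives a number 12.5 percentage points lower from compound 2 to compound 4 (beyond the scatter), the first comparison here between compounds that differ in one place. It shows that removing one carbon from this saturated chain can move the read-out, though a single pair establishes no trend. Nothing available here explains the change. As far as these compounds go, whether butyl in place of propyl would raise the read-out, or methyl in place of ethyl would lower it, remains open.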